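The source may hold more compounds than are shown below. What is called first, only, known or untested is meant among the compounds shown, and "the series" means these compounds.

Measured compounds:

compound 1 `CCC/N=C(\S)OC[C@H]1OC(n2cnc3c(NC4CCOC4)ncnc32)[C@H](O)[C@@H]1O` — 50 nM
compound 2 `O[C@@H]1[C@@H](CO/C(S)=N/C2CCCCC2)OC(n2cnc3c(NC4CCOC4)ncnc32)[C@@H]1O` — 253 nM

Both compounds share the same core and differ only at the group carried on the oxygen of the saturated chain carbon. In an assay on DDT1 cells (Cricetulus griseus) for binding affinity to adenosine receptor A1 (Homo sapiens), read by radioligand binding (a lower number here means a stronger inhibitor, a higher number a weaker inhibitor), compound 1 gives 50 nM; compound 2 gives 253 nM in this assay. For the measured compounds named here, the single step measured so far, a 5.1-fold higher number from compound 1 to compound 2 (0.70 log units; beyond the scatter), places compound 2 at the higher end of the two numbers in hand, with compound 1 the nearer and lower of the pair.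

Compound 3 `O=C(NCc1ccccc1)OC[C@H]1OC(n2cnc3c(NC4CCOC4)ncnc32)[C@H](O)[C@@H]1O` is not yet measured. It differs from compound 2 in this way: a group of 10 heavy atoms (8 carbon, 1 nitrogen, 1 oxygen; one six-membered aromatic ring of carbon only) in place of a group of 9 heavy atoms (7 carbon, 1 nitrogen, 1 sulfur; one six-membered non-aromatic ring of carbon only), on an oxygen on a saturated carbon. Going by the values given here, no measured step covers this exchange; the one step available, a 5.1-fold higher number from compound 1 to compound 2 (0.70 log units; beyond the scatter), concerns a different change on a double-bonded nitrogen and so bears on the present step only loosely, as a sign that this position tolerates changes of modest size in this assay. Among the compounds with values here, with no closer precedent, compound 3 is expected to land near compound 2, with a modest step of a 1.7-fold lower number from compound 2 to compound 3 (0.23 log units; within the scatter) as the working guess, in either direction or none beyond the scatter. The estimate for compound 3 in this assay is 150 nM, within a range from 40 nM to 600 nM.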

Compound 3, inhibition constant: 1830 nM
Estimate against measurement, compound 3: 12-fold (1.09 log units) below; measured number outside the range, above it.
By their numbers in this assay, from the lowest: compound 1; then compound 2; then compound 3.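

In this assay the group on an oxygen on a saturated carbon proves less tolerant than the first pair alone could show: benzylcarbamoyl in place of the cyclohexyl-bearing group gives a 7.2-fold higher number from compound 2 to compound 3 (0.86 log units; beyond the scatter) and in place of the propyl-bearing group gives a 37-fold higher number from compound 1 to compound 3 (1.56 log units; beyond the scatter) as the largest step in the set. Heavy-atom count does not account for the order of these three compounds, since the group entering in compound 3 is only slightly larger by count than the one leaving compound 2, and the counts of hydrogen-bond donors and acceptors stay the same. The exchange swaps the ring type and replaces sulfur with oxygen in one step, and no supporting data are available to explain the loss.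

The compounds shown do not separate the aromatic ring from the change in the linking group, which propylcarbamoyl or cyclohexylcarbamoyl on the same oxygen would address. As far as these compounds go, how a benzyl group on the sulfur-bearing linkage, or a longer chain ending in an amine, would read in this assay also stays open.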